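The compounds below may be only part of what the source reports. "The series", "measured", "known", "first", "only" and "open" are said of these compounds alone.

Working notes on the series. In a functional assay on RKOp27 cells (Homo sapiens) for cytotoxicity, read by MTT assay, with a stated time of 3 days (a lower number here means a stronger inhibitor, a higher number a weaker inhibitor), compound 2 `CNc1nc(SCc2nc3ccccc3[nH]2)nc(-c2ccccc2)c1C#N` gives 3.7 nM, within the scatter of both compound 1 `N#Cc1c(Cl)nc(SCc2nc3ccccc3[nH]2)nc1-c1ccccc1` at 4.38 nM and compound 3 `N#Cc1c(NC(N)=S)nc(SCc2nc3ccccc3[nH]2)nc1-c1ccccc1` at 2.63 nM. Compound 4 `CN1CCN(c2nc(SCc3nc4ccccc4[nH]3)nc(-c3ccccc3)c2C#N)CC1` carries 4-methylpiperazin-1-yl in place of methylamino on an aromatic carbon. Three measured exchanges at this same carbon bear on the change: a 1.2-fold lower number from compound 1 to compound 2 (0.07 log units; within the scatter), a 1.7-fold lower number from compound 1 to compound 3 (0.22 log units; within the scatter) and a 1.4-fold lower number from compound 2 to compound 3 (0.15 log units; within the scatter). All three lie within the scatter, although none introduces a ring, so they give only limited support. No shift beyond the scatter is therefore expected in this assay, and no direction is favoured. The estimated step is a 1.1-fold higher number from compound 2 to compound 4 (0.03 log units; within the scatter). For compound 4 the expected value is 4 nM, with an estimated range of 1.6 nM to 11 nM.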

Compound 4, half-maximal inhibitory concentration: 5.4 nM
Beside the measured number, compound 4's estimate is 1.4-fold (0.13 log units) below it; measured number inside the range.
By their numbers in this assay, from the lowest: compounds 3, 2, 1 and 4 (each within the scatter of the next, the first and the last beyond it).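

In this assay the first ring at this carbon, 4-methylpiperazin-1-yl, which has 0 hydrogen-bond donors, gives a 1.5-fold higher number from compound 2 to compound 4 (0.16 log units; within the scatter) and a 1.2-fold higher number from compound 1 to compound 4 (0.09 log units; within the scatter) as its steps from the two smaller groups. Going by these compounds alone, the only step at this carbon so far to pass the scatter is a 2.1-fold higher number from compound 3 to compound 4 (0.31 log units; beyond the scatter), and it is modest. Nothing available accounts for these steps. The compounds shown leave open how a morpholin-4-yl or piperidin-1-yl ring, or a carboxylic acid, at this carbon would read in this assay. They also leave open whether changes elsewhere on the shared core would give larger steps.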